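Adding a Fluoro to Compound 3: An Expected Step

This account rests on a few compounds, and the source may have more. Where it says the series, first, only, none or still open, it means among the compounds named here.

Of the compounds shown here, three sharing one core have been measured in a functional assay on HT-29 cells (Homo sapiens) for cytotoxicity, read by MTT assay, with a stated time of 72 h; a higher number here means a weaker inhibitor, a lower number a stronger inhibitor. Compound 1 `COc1cc2c(Oc3ccc(NC(=O)c4nn(-c5ccccc5)c(=O)c5ccccc45)cc3F)ccnc2cc1OCCCN1CCCCC1` gives 1310 nM. Compound 2 `COc1cc2c(Oc3ccc(NC(=O)c4nn(-c5ccccc5F)c(=O)c5ccccc45)cc3F)ccnc2cc1OCCCN1CCCCC1` gives 630 nM, and compound 3 `COc1cc2c(Oc3ccc(NC(=O)c4nn(-c5ccccc5)c(=O)c5ccccc45)cc3F)ccnc2cc1OCCCN1CCC(C)CC1` gives 1040 nM. Two single changes connect them. The fluoro in place of hydrogen on an aromatic carbon brought a 2.1-fold lower number from compound 1 to compound 2 (0.32 log units; beyond the scatter), while the methyl in place of hydrogen on a saturated ring carbon brought a 1.3-fold lower number from compound 1 to compound 3 (0.10 log units; within the scatter). Compound 3 therefore sits close to compound 1, within the usual scatter of this assay, and its gap to compound 2 also stays within that scatter.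

Compound 4 `COc1cc2c(Oc3ccc(NC(=O)c4nn(-c5ccccc5F)c(=O)c5ccccc45)cc3F)ccnc2cc1OCCCN1CCC(C)CC1` has not yet been measured. It differs from compound 3 by fluoro in place of hydrogen on an aromatic carbon. Among the measured compounds shown here, the only measured step that bears on this change is the one from compound 1 to compound 2, which carried the same fluoro into the same kind of position and gave a modest improvement beyond the scatter. Carrying that over, compound 4 is expected to show a 2.1-fold lower number from compound 3 to compound 4 (0.32 log units; beyond the scatter) in this assay. On that basis compound 4 is estimated at 500 nM, with a range from 250 nM to 1000 nM.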

Compound 4, half-maximal inhibitory concentration: 510 nM
The estimate for compound 4 lay 1.0-fold (0.01 log units) below the measured number; the range from low to high includes it.
By their numbers in this assay, from the lowest: compounds 4, 2, 3 and 1 (each within the scatter of the next, the first and the last beyond it).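

Until now, the effect of the fluoro rested on a single step. In this assay, the change from phenyl to 2-fluorophenyl now gives a 2.0-fold lower number from compound 3 to compound 4 (0.31 log units; beyond the scatter), this time on a core that also carries the methyl on the saturated ring. The fluoro at this place, on an aromatic carbon ortho to a large group, therefore gave matching steps on both cores: the same change on two cores in this assay, a 2.1-fold lower number (0.32 log units; beyond the scatter) from compound 1 to compound 2 and a 2.0-fold lower number (0.31 log units; beyond the scatter) from compound 3 to compound 4, 1.0-fold (0.01 log units) apart, within the scatter of two such steps The methyl step, read with the fluoro already present, gives a 1.2-fold lower number from compound 2 to compound 4 (0.09 log units; within the scatter), so it stays within the scatter with or without the fluoro, and the two changes show no sign of interfering with each other: the same change on two cores in this assay, a 1.3-fold lower number (0.10 log units; within the scatter) from compound 1 to compound 3 and a 1.2-fold lower number (0.09 log units; within the scatter) from compound 2 to compound 4, 1.0-fold (0.01 log units) apart, within the scatter of two such steps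

Two cores are still too few for a general rule, and these compounds cannot show why the fluoro gives a lower number. They also leave open whether a chloro, a methoxy or a nitrile at this place would give a similar step, and whether a fluoro on another carbon of the same ring would do so.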